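The source may report more compounds than this note shows. Statements on the series, on what has been measured and on what is new or still open speak of the compounds shown alone.

In a functional assay on HBL-100 cells (Homo sapiens) for inhibition, read by sulforhodamine B assay, with a stated time of 48 h (a higher number here means a weaker inhibitor of growth, a lower number a stronger inhibitor of growth), compound 3 `C=C(C/C(=C\c1ccc(Cl)cc1)C(=O)c1ccccc1)C(=O)c1ccccc1` gives 17000 nM, the lowest of the two numbers shown. Compound 2 `O=C(OC/C(=C/c1ccc(Cl)cc1Cl)C(=O)c1ccccc1)c1ccccc1` gives 26000 nM in this assay, a value that lies within the scatter of compound 3. Compound 1 `CC(=O)OC/C(=C/c1ccccc1[N+](=O)[O-])C(=O)c1ccccc1` reaches only > 100000 nM in this assay, which is a limit of the measurement rather than a number (the limit of > 100000 nM in this assay, at which 1 of the 3 values shown sits). Compound 4 `C=C(C/C(=C\c1ccc(OC)cc1)C(=O)c1ccccc1)C(=O)c1ccccc1` has not yet been measured; it differs from compound 3 by methoxy in place of chloro on an aromatic carbon. Among the compounds with values here, no measured pair shows this change, so its size cannot be read from the data. Compound 4 is expected to give about 20000 nM, between 8000 nM and 50000 nM, in this assay. The estimated step of a 1.2-fold higher number from compound 3 to compound 4 (0.07 log units; within the scatter) is expected to stay within the scatter.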

Compound 4, concentration for 50% growth inhibition: 530 nM
Estimate against measurement, compound 4: 38-fold (1.58 log units) above; measured number below the stated range.
By their numbers in this assay, from the lowest: compound 4; then compounds 3 and 2 (each within the scatter of the next). At a limit, above all of these: compound 1.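

In this assay, replacing chloro with methoxy on an aromatic carbon, para to a large group, gives a 32-fold lower number from compound 3 to compound 4 (1.51 log units; beyond the scatter). Within the data shown here, this is the first pair here that differs in one place, and it shows that this position can strongly change growth inhibition while the rest of the structure stays the same. No measurement shown here bears on the reason for this change.

From the compounds shown here alone, it remains open whether an amine, a hydroxyl or a longer alkoxy chain at this position would keep the gain. Going by these compounds, whether methoxy would act alike on the cores of compound 1 and compound 2 also remains open.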